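Chloro in place of hydrogen at a toxicity limit

A few compounds are considered here, and "the series" means these few. Any claim that something is new, unique, unknown or untested is made for them only; others in the source may bear on it.

In an ADME assay on MT4 cells (Homo sapiens) for cytotoxicity, read by MTT assay, with a stated time of 96 h (on this read-out higher numbers stand for lower toxicity in this test and lower numbers for higher toxicity in this test), compound 2 `c1ccc(/N=N/N2CCCCC2)cc1` gives > 100000 nM as its reading, which is a limit and not a number. Compound 1 `Clc1cccc(/N=N/N2CCCCC2)c1` gives > 100000 nM as its reading, again a limit. Compound 3 `Brc1cccc(/N=N/N2CCCCC2)c1` gives > 100000 nM as its reading, also a limit. Compound 2 therefore has no exact place in the series, and what the three share is the limit of > 100000 nM in this assay, at which 3 of the 3 values shown sit, so no ranking can be read from them.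

The step in question leads to compound 4 `Clc1ccc(/N=N/N2CCCCC2)cc1`, which carries chloro in place of hydrogen on an aromatic carbon. The closest measured change is a step that the two limits leave unreadable from compound 1 to compound 2, where hydrogen replaces chloro on an aromatic carbon. The same holds for a step that the two limits leave unreadable from compound 1 to compound 3 and for a step that the two limits leave unreadable from compound 2 to compound 3, so none of the three has a size that can be stated. Resting on a step that the two limits leave unreadable from compound 1 to compound 2 as the only measured swap between these two groups, no shift in either direction is expected in this assay beyond the scatter. The expected size of a number no higher from compound 2 to compound 4 (the limit leaves the size open) is accordingly none that could be told from the scatter, and a further limit is the likeliest report. For compound 4 the estimate is 100000 nM, with an expected range from 40000 nM to 150000 nM.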

Compound 4, half-maximal cytotoxic concentration: > 100000 nM
Compound 4: a limit, no number (the forecaster's own chance of this, stated with the estimate: 80%); the middle value lies on the limit itself.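

In this assay compound 4 gives > 100000 nM, which is a limit and not a number. For the compounds shown here, no new step can therefore be read from compound 2 to compound 4, and the two limits give that pair no size. The compounds shown leave open whether hydrogen, chloro or bromo on an aromatic carbon changes the toxicity in this test at all: the limit of > 100000 nM in this assay, at which 4 of the 4 values shown sit.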